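Methyl in place of bromo on the aromatic ring

The source may report more compounds than this note shows. Statements on the series, on what has been measured and on what is new or still open speak of the compounds shown alone.

Of the compounds shown here, three of a shared core have been tested in a functional assay on CCRF-CEM cells (Homo sapiens) for antiproliferative activity, read by MTT assay, with a stated time of 3 days; on this read-out lower numbers stand for stronger inhibition and higher numbers for weaker inhibition. Compound 1 `O=C1c2ccccc2C(=O)N1C/C=C\Cn1cc(C#Cc2ccc(Br)cc2)c(=O)[nH]c1=O` gives 80000 nM, compound 2 `CCCCC#Cc1cn(C/C=C/CN2C(=O)c3ccccc3C2=O)c(=O)[nH]c1=O` gives 192000 nM, and compound 3 `O=C1c2ccccc2C(=O)N1C/C=C/Cn1cc(C#CCCc2ccccc2)c(=O)[nH]c1=O` gives 38000 nM. Compound 1 therefore stands second highest of the three numbers, with compound 3 its nearest neighbour at a lower number and compound 2 the furthest at a higher one. Going by the values given here, the only single-place step among them is a 5.1-fold lower number from compound 2 to compound 3 (0.70 log units; beyond the scatter), a change at a saturated chain carbon two bonds along the chain from a triple-bonded carbon.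

Compound 4 `Cc1ccc(C#Cc2cn(C/C=C\CN3C(=O)c4ccccc4C3=O)c(=O)[nH]c2=O)cc1` differs from compound 1 in one place: methyl in place of bromo on an aromatic carbon. Among the compounds with values here, no measured step touches this aromatic carbon or exchanges a halogen for a methyl, so nothing here speaks for a shift in either direction. The change from compound 2 to compound 3 concerns a different part of the molecule and does not bear on it. The expectation is therefore a step of about no change at the digits printed from compound 1 to compound 4 (within the scatter) in this assay, that is, none beyond the scatter. Compound 4 is expected to give around 80000 nM, within a range from 35000 nM to 180000 nM.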

Compound 4, half-maximal inhibitory concentration: 238000 nM
For compound 4 the middle estimate is 3.0-fold (0.47 log units) below the measured one; the whole stated range lies below it.
By their numbers in this assay, from the lowest: compound 3; then compound 1; then compounds 2 and 4 (each within the scatter of the next).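

In this assay, going by these compounds alone, the exchange of bromo for methyl gives a 3.0-fold higher number from compound 1 to compound 4 (0.47 log units; beyond the scatter), which is the first reading at this aromatic carbon and the first for any exchange of a halogen for a methyl. It shows that the number responds to a change at the end of the 2-(4-bromophenyl)ethynyl group, even though one heavy atom simply replaces another and the counts of rings, hydrogen-bond donors, hydrogen-bond acceptors and net charge stay the same. Nothing measured here accounts for this shift.

Within the data shown here, with only this pair at the position, it remains open whether bromo lowers the number relative to other groups on this carbon or methyl raises it, and a chloro, methoxy or unsubstituted phenyl analogue of compound 1 would help to separate those two readings. From the compounds shown here alone, it is also open whether the same exchange would have a similar effect in a compound with the other double-bond geometry of the linking chain, as carried by compound 2 and compound 3.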